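Compound 4: a nitrile enters the ring of compound 2

The source may hold more compounds than are shown below. What is called first, only, known or untested is meant among the compounds shown, and "the series" means these compounds.

Compound 1 `CC(O)(COc1cccc(S(F)(F)(F)(F)F)c1)C(=O)Nc1ccc(S(F)(F)(F)(F)F)cc1` gives 11400 nM
Compound 2 `CC(O)(COc1cccc(C(F)(F)F)c1)C(=O)Nc1ccc(S(F)(F)(F)(F)F)cc1` gives 24700 nM
Compound 3 `CC(O)(COc1cccc(OC(F)(F)F)c1)C(=O)Nc1ccc(S(F)(F)(F)(F)F)cc1` gives 18300 nM

All three values come from a functional assay on VCaP cells (Homo sapiens) for antiproliferative activity, read by propidium iodide staining, with a stated time of 96 h (a higher number here means a weaker inhibitor, a lower number a stronger inhibitor), and are half-maximal inhibitory concentrations. Compound 2 has a close neighbour: the data show a 1.3-fold lower number from compound 2 to compound 3 (0.13 log units; within the scatter) and so these two cannot be told apart. The gap to the remaining compound is modest but clear, with a 2.2-fold higher number from compound 1 to compound 2 (0.34 log units; beyond the scatter) on record.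

Compound 4 `CC(O)(COc1ccc(C#N)c(F)c1)C(=O)Nc1ccc(S(F)(F)(F)(F)F)cc1` has not yet been measured. It carries 4-cyano-3-fluorophenyl in place of 3-(trifluoromethyl)phenyl on an oxygen on a saturated carbon. The closest evidence comes from swapping one group on that ring among the measured compounds. Those swaps moved the number little, as (a 1.6-fold higher number from compound 1 to compound 3 (0.21 log units; within the scatter)) and (a 2.2-fold higher number from compound 1 to compound 2 (0.34 log units; beyond the scatter)) show. None of them brings in a nitrile, so the evidence is indirect and the range has to stay wide. In this assay only a small step is expected, estimated as a 1.2-fold lower number from compound 2 to compound 4 (0.09 log units; within the scatter) and probably lost in the scatter. For compound 4 the estimated value is 20000 nM with an expected range from 7000 nM to 50000 nM in this measurement.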

Compound 4, half-maximal inhibitory concentration: 100000 nM
Beside the measured number, compound 4's estimate is 5.0-fold (0.70 log units) below it, outside the stated range (above it).
By their numbers in this assay, from the lowest: compounds 1, 3 and 2 (each within the scatter of the next, the first and the last beyond it); then compound 4.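

Within the data shown here, the ring on the ether oxygen tolerates less change than the earlier compounds suggested. In this assay, swapping one group on it among the first three compounds moved the number only slightly, with the largest such step being a 2.2-fold higher number from compound 1 to compound 2 (0.34 log units; beyond the scatter), whereas this replacement gives a 4.0-fold higher number from compound 2 to compound 4 (0.61 log units; beyond the scatter), the largest step seen so far. This change removes the trifluoromethyl group and brings in both a nitrile and a fluorine, so the step belongs to the whole replacement and cannot be split between them, and nothing in the data explains why the number rose.

On these data alone, it remains open whether a ring with the nitrile alone or the fluorine alone would give a number closer to that of compound 2 or closer to that of compound 4. As far as these compounds go, it is also open how a chlorine, a methoxy group, an amine or a carboxylic acid would fare on this ring, and whether the same replacement would give a step of similar size if the pentafluorosulfanyl group on the other ring gave way to a chlorine.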